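Hydroxy-methoxyphenyl exchange: from compound 2 to compound 3

A few compounds are considered here, and "the series" means these few. Any claim that something is new, unique, unknown or untested is made for them only; others in the source may bear on it.

In a functional assay on MCF7 cells (Homo sapiens) for antiproliferative activity, read by sulforhodamine B assay, with a stated time of 48 h (on this read-out higher numbers stand for weaker inhibition and lower numbers for stronger inhibition), compound 1 (`COc1cccc(/C=C/C(=O)C(=Cc2cc(OC)c(OC)c(OC)c2)C(=O)/C=C/c2cccc(OC)c2OC)c1OC`) gives 840 nM and compound 2 (`COc1cc(C=C(C(=O)/C=C/c2cccc(OC)c2OC)C(=O)/C=C/c2cccc(OC)c2OC)cc(OC)c1O`) gives 460 nM as its read-out. Within the data shown here, these are the only two numbers so far and they lie within the scatter of each other, so compound 2 holds no firm rank.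

Compound 3 (`COc1ccc(C=C(C(=O)/C=C/c2cccc(OC)c2OC)C(=O)/C=C/c2cccc(OC)c2OC)cc1O`) has not yet been measured. It carries 3-hydroxy-4-methoxyphenyl in place of 4-hydroxy-3,5-dimethoxyphenyl on a double-bonded chain carbon bound to a double-bonded chain carbon. Among the measured compounds shown here, one measured step bears on this, though only indirectly: a 1.8-fold lower number from compound 1 to compound 2 (0.26 log units; within the scatter) for hydrogen in place of methyl on an oxygen on an aromatic ring. That step stays within the scatter. For the measured compounds named here, no measured pair shows this exact exchange, so the direction remains poorly defined, and no change beyond the scatter is expected in this assay for now.

The estimated step is a 1.1-fold higher number from compound 2 to compound 3 (0.05 log units; within the scatter) in this expectation. For compound 3 the estimate is 520 nM with an expected range from 190 nM to 1400 nM on this read-out.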

Compound 3, half-maximal inhibitory concentration: 310 nM
Compound 3: the middle estimate sits 1.7-fold (0.22 log units) above what was measured, within the range that was stated.
By their numbers in this assay, from the lowest: compounds 3, 2 and 1 (each within the scatter of the next, the first and the last beyond it).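

In this assay 3-hydroxy-4-methoxyphenyl can stand in place of 4-hydroxy-3,5-dimethoxyphenyl on a double-bonded chain carbon bound to a double-bonded chain carbon without a change beyond the scatter (a 1.5-fold lower number from compound 2 to compound 3 (0.17 log units; within the scatter)), so this position accepts a second hydroxy-bearing aryl group with a different pattern of methoxy groups. Among these compounds, the same place now also gives the first step that lies beyond the scatter, though only a modest one, when 3-hydroxy-4-methoxyphenyl replaces 3,4,5-trimethoxyphenyl (a 2.7-fold lower number from compound 1 to compound 3 (0.43 log units; beyond the scatter)), and compound 2 lies within the scatter of both of the other compounds. No measured data are at hand to explain these numbers.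

The step beyond the scatter changes the hydroxy group and the number of methoxy groups together, so the share of each in it stays unresolved within these three compounds. Also open, as far as these compounds go, is how this position responds to a group of another kind on the aryl ring, such as an amine or a carboxylic acid in place of the hydroxy group.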